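Swapping the thiophene amide for a chlorophenyl amide

The source may hold more compounds than are shown below. What is called first, only, known or untested is meant among the compounds shown, and "the series" means these compounds.

The measured compounds and their numbers in a functional assay on HUVEC cells (Homo sapiens) for inhibition; on this read-out lower numbers stand for stronger inhibition and higher numbers for weaker inhibition:
compound 1, `COC(=O)C(=O)Nc1cccc(C(=O)/C=C/c2ccc(O)c(OC)c2)c1`, 1.5 ug/mL;
compound 2, `CCOC(=O)C(=O)Nc1cccc(C(=O)/C=C/c2ccc(O)c(OC)c2)c1`, 13.3 ug/mL;
compound 3, `COc1cc(/C=C/C(=O)c2cccc(NC(=O)c3cccs3)c2)ccc1O`, 0.38 ug/mL.

Compound 3 gives the lowest number of the three in this assay. Its nearest neighbour is compound 1, with a 3.9-fold lower number from compound 1 to compound 3 (0.60 log units; beyond the scatter); the step of a 35-fold lower number from compound 2 to compound 3 (1.54 log units; beyond the scatter) is the widest gap in the set. Between the two esters, an 8.9-fold higher number from compound 1 to compound 2 (0.95 log units; beyond the scatter) separates compound 1 from compound 2.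

Compound 4, `COc1cc(/C=C/C(=O)c2cccc(NC(=O)c3ccc(Cl)cc3)c2)ccc1O`, differs from compound 3 in one place: 4-chlorophenyl in place of thiophen-2-yl on a carbonyl carbon. Among the compounds with values here, none of the measured steps changes one aromatic ring on the carbonyl carbon for another; the two steps leading to compound 3 replace an ester by an aromatic ring and both lower the number. Compound 4 keeps an aromatic ring in that position, so no step beyond the scatter is firmly expected in this assay, and a number close to compound 3 is estimated, with a 1.3-fold higher number from compound 3 to compound 4 (0.12 log units; within the scatter) as the expected step. For compound 4 the estimate is 0.5 ug/mL, expected to fall between 0.15 ug/mL and 1.6 ug/mL.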

Compound 4, half-maximal inhibitory concentration: 0.76 ug/mL
Beside the measured number, compound 4's estimate is 1.5-fold (0.18 log units) below it, within the range that was stated.
By their numbers in this assay, from the lowest: compounds 3, 4 and 1 (each within the scatter of the next, the first and the last beyond it); then compound 2.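

In this assay, within the data shown here, this is the first exchange of one aromatic ring for another on this carbonyl carbon, and the step, a 2.0-fold higher number from compound 3 to compound 4 (0.30 log units; within the scatter), stays within the scatter, so thiophen-2-yl and 4-chlorophenyl cannot be told apart here. Against the esters the result divides: 4-chlorophenyl in place of ethoxycarbonyl gives an 18-fold lower number from compound 2 to compound 4 (1.24 log units; beyond the scatter), while 4-chlorophenyl in place of methoxycarbonyl gives a 2.0-fold lower number from compound 1 to compound 4 (0.30 log units; within the scatter), which lies within the scatter, so the gain seen for thiophen-2-yl over methoxycarbonyl does not carry over beyond the scatter to this ring. Nothing available explains any of these steps.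

On these data alone, what the chlorine itself contributes stays open, as does how a plain phenyl or a cyclohexyl group on this carbonyl carbon would read in this assay. The compounds shown also leave open how a carboxylic acid in place of the ester would behave.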